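Changing one sulfonamide nitrogen group on compound 2

The compounds below may be only part of what the source reports. "The series", "measured", "known", "first", "only" and "open" are said of these compounds alone.

Of the compounds shown here, three sharing a core have been measured in an in vitro ADME assay on microsomes from liver (Homo sapiens) for metabolic stability, read by LC-MS, tested at 1 uM; on this read-out lower numbers stand for slow clearance and higher numbers for fast clearance. Compound 1 `CCCS(=O)(=O)c1cccc(C#Cc2cc(Cl)ccc2OCC(=O)O)c1` gives 11 mL.min-1.g-1, compound 3 `CCCS(=O)(=O)c1ccc(F)c(C#Cc2cc(Cl)ccc2OCC(=O)O)c1` gives 12 mL.min-1.g-1, and compound 2 `COCCN(C)S(=O)(=O)c1ccc(C)c(C#Cc2cc(Cl)ccc2OCC(=O)O)c1` gives 32 mL.min-1.g-1, the highest of the three numbers and beyond the scatter from the other two.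

Compound 4 `Cc1ccc(S(=O)(=O)N(C)C(C)C)cc1C#Cc1cc(Cl)ccc1OCC(=O)O` is still unmeasured. It differs from compound 2 in one place: isopropyl in place of 2-methoxyethyl on a sulfonamide nitrogen. In words, isopropyl stands in place of 2-methoxyethyl on a sulfonamide nitrogen.

Among the compounds with values here, only one measured step changes a single place: a 1.1-fold higher number from compound 1 to compound 3 (0.04 log units; within the scatter). That step, within the scatter, puts fluoro in place of hydrogen on an aromatic carbon, so it concerns a different place and offers only weak guidance. Within the data shown here, no measured step changes the group on a sulfonamide nitrogen, so the data give no direction for this change. The starting point is therefore compound 2 at 32 mL.min-1.g-1, and no shift beyond the scatter is expected in this assay. The expected step is small: a 1.1-fold lower number from compound 2 to compound 4 (0.03 log units; within the scatter). The estimate for compound 4 is 30 mL.min-1.g-1, with an expected range from 14 mL.min-1.g-1 to 62 mL.min-1.g-1.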

Compound 4, intrinsic clearance in microsomes: < 10 mL.min-1.g-1
Compound 4 was reported as a limit; the forecaster's own chance of this, stated with the estimate: 3%; middle value at least 3.0-fold (0.47 log units) from the limit.
By their numbers in this assay, from the lowest: compounds 1 and 3 (each within the scatter of the next); then compound 2. At a limit, below all of these: compound 4.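

Within the data shown here, putting isopropyl in place of 2-methoxyethyl on a sulfonamide nitrogen gives an at least 3.2-fold lower number from compound 2 to compound 4 (0.50 log units; beyond the scatter) in this assay, so this group, which no earlier step touched, clearly affects the read-out. Compound 4 gives < 10 mL.min-1.g-1, which is a limit of the assay and not a number. The full size of the step therefore cannot be read: the limit of < 10 mL.min-1.g-1 in this assay, at which 1 of the 4 values shown sits.

Isopropyl differs from 2-methoxyethyl both in having no oxygen and in its number of heavy atoms, so the compounds shown leave open which of these differences goes with the lower number. Also open, on these data alone, is what an ethyl group, a cyclopropyl ring or a chain ending in an amine would give on this sulfonamide nitrogen.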